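The source may report more compounds than this note shows. Statements on the series, on what has been measured and on what is new or still open speak of the compounds shown alone.

Of the compounds shown here, three have so far been measured in a functional assay for antagonist activity at transient receptor potential cation channel subfamily V member 1 (Rattus norvegicus), read by FLIPR; a higher number here means a more potent compound, by a factor of ten per unit of this negative logarithm, a lower number a less potent compound. Compound 1, `O=C(Nc1ccccc1Br)N[C@@H]1CCN(c2ccc(F)c(F)c2)C1`, gives 8.1. Compound 2, `O=C(Nc1ccccc1Br)N[C@@H]1CCN(c2cccc(F)c2)C1`, gives 7.8. The two differ by hydrogen in place of fluoro on an aromatic carbon, and the step was a number 0.30 log units lower from compound 1 to compound 2 (within the scatter). Compound 3, `O=C(NCCN1CCc2c(F)cccc21)Nc1ccccc1Br`, has a different core; how its core differs from that of compound 1 is not broken down here. In this assay compound 3 gives 7.4, the lowest of the three values, and its gaps to compound 2 and to compound 1 are both beyond the scatter.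

Compound 4, `O=C(NCCN1CCc2ccccc21)Nc1ccccc1Br`, has not yet been measured. It differs from compound 3 by hydrogen in place of fluoro on an aromatic carbon. This is the same kind of change as that from compound 1 to compound 2, but the surroundings differ: there the carbon was ortho to a fluoro group and para to a large group, here it is part of a fused or bridged system of two rings, ortho to a fused ring and meta to a fused ring. The step is expected to be a number 0.30 log units lower from compound 3 to compound 4 (within the scatter), resting on the earlier step of a number 0.30 log units lower from compound 1 to compound 2 (within the scatter), with added uncertainty from the changed surroundings. Compound 4 is therefore estimated at 7.1.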

Compound 4, negative logarithm of the antagonist equilibrium constant: 6.8
For compound 4 the middle estimate is 0.30 log units above the measured one, within the range that was stated.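

Replacing the fluoro group with hydrogen on the core of compound 3 gives, in this assay, a number 0.60 log units lower from compound 3 to compound 4 (beyond the scatter). Set beside the earlier case, the two steps cannot be told apart, so on these two cores the change carries over as well as such data can show: the same change on two cores in this assay, a number 0.30 log units lower (within the scatter) from compound 1 to compound 2 and a number 0.60 log units lower (beyond the scatter) from compound 3 to compound 4, 0.30 log units apart, within the scatter of two such steps. Among the compounds shown here, this does not prove that the steps are equal, or that the change behaves the same way across the series, since each core offers a single pair of compounds and only the step on the core of compound 3 lies beyond the scatter.

The compounds shown leave open whether a different group on the same aromatic carbon, such as chloro, methoxy or a nitrile, would match fluoro or hydrogen on either core. They also leave open whether the step would hold on further cores, for example one carrying a longer chain.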